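Methyl for phenylethenyl on the chain carbon: compound 4

The source may hold more compounds than are shown below. What is called first, only, known or untested is meant among the compounds shown, and "the series" means these compounds.

Measured so far:
compound 1 `Nc1nc(O)c2c(n1)n(C1OC(CO)[C@@H](O)[C@H]1O)c(=O)n2C/C=C/c1ccccc1` gives 5%
compound 2 `C=CCn1c(=O)n(C2C[C@H](O)C(CO)O2)c2nc(N)nc(O)c21` gives 131%
compound 3 `Cn1c(=O)n(C2OC(CI)[C@@H](O)[C@H]2O)c2nc(N)nc(O)c21` gives 4%

In a functional assay on the whole organism with Mus musculus as the target (on this read-out higher numbers stand for larger maximal responses and lower numbers for smaller maximal responses), compound 1 stands second of the three numbers. Its nearest neighbour is compound 3, whose value lies within the scatter of that of compound 1, so no order between them can be claimed. Compound 2 stands far beyond the scatter above both.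

Compound 4 `CCn1c(=O)n(C2OC(CO)[C@@H](O)[C@H]2O)c2nc(N)nc(O)c21` has not yet been measured. It differs from compound 1 by methyl in place of 2-phenylethenyl on a saturated chain carbon bound to an aromatic nitrogen. Compound 3 carries a methyl on the same aromatic nitrogen and gives a low number, but it differs further along the molecule, so it gives no clean guide. Compound 2, with a short unsaturated chain on that nitrogen, gives the only large response.

Among the compounds with values here, with no measured step of this kind, the direction is open. A rise beyond the scatter seems somewhat more likely than none, because the low value 5% of compound 1 leaves room above. The estimated step of a number 35 percentage points higher from compound 1 to compound 4 (beyond the scatter) is expected to be upward. Compound 4 is expected at 40%, within 3% to 130%.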

Compound 4, largest response reached (reported as maximal response), in percent of the reference or control that the assay uses: 82%
Compound 4: the middle estimate sits 42 percentage points below what was measured; the measured number falls inside the stated range.
By their numbers in this assay, from the lowest: compounds 3 and 1 (each within the scatter of the next); then compound 4; then compound 2.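

In this assay, within the data shown here, the change from 2-phenylethenyl to methyl on a saturated chain carbon bound to an aromatic nitrogen gives a number 77 percentage points higher from compound 1 to compound 4 (beyond the scatter) and is the first clean single-place step. The response therefore depends strongly on the group in this place, since the 3-phenylprop-2-en-1-yl and ethyl chains give clearly separate values with the rest of the molecule unchanged. No measurement shown bears on the reason for this step.

The change removes the six-membered aromatic ring and the double bond together, so the compounds shown cannot divide the step between them. On these data alone, a 3-phenylpropyl chain, which keeps the ring without the double bond, and a propyl chain would help separate these parts, while an amine at the chain end remains open as well.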